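Removing One Methyl From the Amide Side Chain

This account rests on a few compounds, and the source may have more. Where it says the series, first, only, none or still open, it means among the compounds named here.

Measured compounds:
- compound 1 `Cc1ccc(CC(CNC(=O)C(C)(C)c2ccc(NS(C)(=O)=O)cc2)COC(=O)C(C)(C)C)cc1C`: 370 nM
- compound 2 `Cc1ccc(CC(CNC(=O)C(C)(C)c2ccc(NS(C)(=O)=O)c(F)c2)COC(=O)C(C)(C)C)cc1C`: 280 nM

Compound 1 and compound 2 were both tested in an assay on CHO cells for displacement of a labelled ligand from transient receptor potential cation channel subfamily V member 1 (Rattus norvegicus); on this read-out lower numbers stand for stronger inhibition and higher numbers for weaker inhibition. Compound 1 gives 370 nM and stands as the higher of the two numbers, yet the step of a 1.3-fold lower number from compound 1 to compound 2 (0.12 log units; within the scatter) lies within the scatter, so the two compounds cannot be told apart on this read-out.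

Compound 3 `Cc1ccc(CC(CNC(=O)C(C)c2ccc(NS(C)(=O)=O)cc2)COC(=O)C(C)(C)C)cc1C` has not been measured. It differs from compound 1 by hydrogen in place of methyl on a saturated chain carbon bound to an aromatic carbon, a carbonyl carbon and a saturated chain carbon. Among the compounds with values here, the only measured step, from compound 1 to compound 2, concerns a fluoro on an aromatic carbon and does not touch the saturated chain carbon changed here, so no measured step bears on this change. With nothing to lean on, a modest change in either direction is plausible, and a mild weakening is taken as the central guess.

Compound 3 is therefore expected to show a 1.6-fold higher number from compound 1 to compound 3 (0.21 log units; within the scatter) relative to compound 1, with its value in this assay estimated at 600 nM, within a range of 200 nM to 2000 nM.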

Compound 3, inhibition constant: 119 nM
Compound 3: middle estimate off by 5.0-fold (0.70 log units), on the high side, outside the stated range (below it).
By their numbers in this assay, from the lowest: compound 3; then compounds 2 and 1 (each within the scatter of the next).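

Losing one of the two methyl groups on this saturated chain carbon is not a neutral change: in this assay, hydrogen in place of methyl gives a 3.1-fold lower number from compound 1 to compound 3 (0.49 log units; beyond the scatter) and so lies beyond the scatter, though the step is modest. The fluoro step stayed within the scatter, which makes this chain carbon the first place in the series where a change can be read as a real gain in inhibition. Nothing at hand explains the gain, so it stands as an observation only.

Still open, going by these compounds, is how the number would respond to a second hydrogen in place of the remaining methyl, or to an ethyl or hydroxyl group on the same carbon. On these data alone, it is also open whether the fluoro on the aromatic carbon would matter in a compound carrying hydrogen at this chain carbon.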